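The compounds below may be only part of what the source reports. "The series", "measured", "known", "first", "only" and "open" are said of these compounds alone.

Measured so far, all in an assay for displacement of a labelled ligand from Sigma non-opioid intracellular receptor 1 (Cavia porcellus), read by scintillation counting, with a stated time of 180 min; a lower number here means a stronger inhibitor, a higher number a weaker inhibitor:

Compound 1, `CC1(C)COC(CCCN2CCc3cc(OCc4ccccc4)ccc3C(O)C2)(c2ccc(C(C)(C)C)cc2)OC1`: compound 1 gives > 1000 nM, which is a limit of the assay and not a number.
Compound 2, `CC1(C)COC(CCCN2CCc3cc(OCc4ccccc4)ccc3C(O)C2)(c2ccc(F)cc2)OC1`: compound 2 gives > 1000 nM, again a limit.
Compound 3, `CC(C)(C)c1ccc(C(=O)CCCN2CCc3cc(OCc4ccccc4)ccc3C(O)C2)cc1`: compound 3 gives > 1000 nM, also a limit.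

Compound 1 and compound 2 differ in one place only: fluoro in place of tert-butyl on an aromatic carbon. The step this made is a step that the two limits leave unreadable from compound 1 to compound 2, so the two limits leave its size unreadable. Compound 3 carries a different core from compound 1, and the difference between the two cores is not broken down here.

Compound 4, `O=C(CCCN1CCc2cc(OCc3ccccc3)ccc2C(O)C1)c1ccc(F)cc1`, has not yet been measured. It differs from compound 3 by fluoro in place of tert-butyl on an aromatic carbon, the same change as from compound 1 to compound 2, at the same place.

For the step from compound 3 to compound 4, a change of a step that the limit leaves unreadable from compound 3 to compound 4 is expected; this rests on (the limit of > 1000 nM in this assay, at which 3 of the 3 values shown sit), at which every measured value sits, and on the unreadable size of the earlier step. Compound 4 is therefore expected to give about 3000 nM, within 1000 nM to 10000 nM, most likely again as a limit.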

Compound 4, inhibition constant: 293 nM
Compound 4: middle estimate off by 10-fold (1.01 log units), on the high side; measured number outside the range, below it.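

In this assay, putting fluoro in place of tert-butyl on the core of compound 3 gives an at least 3.4-fold lower number from compound 3 to compound 4 (0.53 log units; beyond the scatter), so the change clearly lowers the number on this core. Compound 3 gives > 1000 nM, which is a limit and not a number, so this step has a known minimum but no known full size. The same change on the core of compound 1 cannot be read, so nothing shows whether the effect carries from one core to the other, because the values on that core are limits and not numbers: the limit of > 1000 nM in this assay, at which 3 of the 4 values shown sit.

The compounds shown leave open whether a chloro or methoxy group in the same place would also lower the number, or whether the effect is particular to fluoro. They also leave open how compound 4 would respond to a longer chain between its carbonyl and the ring nitrogen, or to an amine in place of that carbonyl.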